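Series notes: arylthio to alkylthio swap at the sulfur-bound chain carbon

The source may report more compounds than this note shows. Statements on the series, on what has been measured and on what is new or still open speak of the compounds shown alone.

Measured compounds in a functional assay on MCF7 cells (Homo sapiens) for inhibition, read by MTT assay, with a stated time of 72 h; on this read-out lower numbers stand for stronger inhibition and higher numbers for weaker inhibition:
- compound 1 `Cc1cc(Nc2cc(-c3ccccc3)[nH]n2)n2nc(SCc3c(Cl)cccc3Cl)nc2n1`: 3230 nM
- compound 2 `Cc1cc(Nc2cc(-c3ccccc3)[nH]n2)n2nc(SCc3cccc(Br)c3)nc2n1`: 5140 nM
- compound 3 `Cc1cc(Nc2cc(-c3ccc(Cl)cc3)[nH]n2)n2nc(SCc3ccc(Br)cc3)nc2n1`: 3620 nM

Compound 2 gives the highest of the three numbers, but its gaps to compound 3 and to compound 1 both fall within the scatter, so the three are indistinguishable on these data. The step from compound 2 to compound 4 `CCCSc1nc2nc(C)cc(Nc3cc(-c4ccccc4)[nH]n3)n2n1` is ethyl in place of 3-bromophenyl on a saturated chain carbon bound to a sulfur. Among the measured compounds shown here, no measured step covers this kind of change; the only single-point step, a 1.6-fold higher number from compound 1 to compound 2 (0.20 log units; within the scatter), concerns an exchange of one ring for another on the same chain carbon and stayed within the scatter. For compound 4 a modest rise in number is expected, a 1.8-fold higher number from compound 2 to compound 4 (0.24 log units; within the scatter), with wide uncertainty. Compound 4 is therefore estimated at 9000 nM, in the range 3500 nM to 25000 nM.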

Compound 4, half-maximal inhibitory concentration: > 50000 nM
Compound 4: only a limit was reported; the forecaster's own chance of this, stated with the estimate: 15%; middle value at least 5.5-fold (0.74 log units) away from the limit.
By their numbers in this assay, from the lowest: compounds 1, 3 and 2 (each within the scatter of the next). At a limit, above all of these: compound 4.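

In this assay compound 4 gives only a limit, > 50000 nM. Ethyl in place of 3-bromophenyl on a saturated chain carbon bound to a sulfur gives an at least 9.7-fold higher number from compound 2 to compound 4 (0.98 log units; beyond the scatter), and ethyl in place of 2,6-dichlorophenyl gives an at least 15-fold higher number from compound 1 to compound 4 (1.18 log units; beyond the scatter). Among the compounds shown here, the only earlier step, one ring for another, stayed within the scatter, whereas both steps that remove the ring lie beyond it, so this position does respond to the change.

Open, from the compounds shown here alone, is whether cyclohexyl or unsubstituted phenyl on the same chain carbon would keep the numbers of compound 1 and compound 2. Going by these compounds, the full size of both steps also stays unknown.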